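A Second Chloro on Compound 1

This account rests on a few compounds, and the source may have more. Where it says the series, first, only, none or still open, it means among the compounds named here.

Compound 1 `CC(C)(C)NCc1c(C(=O)O)nn(-c2ccccc2)c1-c1ccc(Cl)cc1` gives 353000 nM
Compound 2 `Cc1ccc(-c2c(CNC(C)(C)C)c(C(=O)O)nn2-c2ccccc2)cc1` gives > 688000 nM (a limit)
Compound 3 `COc1ccc(-c2c(CNC(C)(C)C)c(C(=O)O)nn2-c2ccccc2)cc1` gives > 659000 nM (a limit)

Within the data shown here, in a functional assay on HT-29 cells (Homo sapiens) for inhibition, read by sulforhodamine B assay, with a stated time of 48 h (on this read-out higher numbers stand for weaker inhibition of growth and lower numbers for stronger inhibition of growth), compound 1 gives 353000 nM, the only true number among the three. Compound 2 gives > 688000 nM, which is a limit. Compound 3 gives > 659000 nM, which is also a limit.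

Compound 4 `CC(C)(C)NCc1c(C(=O)O)nn(-c2ccc(Cl)cc2)c1-c1ccc(Cl)cc1` has not yet been measured. It differs from compound 1 by chloro in place of hydrogen on an aromatic carbon, so that phenyl becomes 4-chlorophenyl.

Among the measured compounds shown here, two measured steps bear on this change, though only indirectly. These are an at least 1.9-fold higher number from compound 1 to compound 2 (0.28 log units; that floor lies within the scatter) and an at least 1.8-fold higher number from compound 1 to compound 3 (0.27 log units; that floor lies within the scatter), and both floors lie within the scatter. Both replace the chloro already present in compound 1 and leave the phenyl untouched, so they offer weak guidance. The step expected is a 1.4-fold lower number from compound 1 to compound 4 (0.15 log units; within the scatter), a slight move toward stronger inhibition of growth that is not expected to exceed the scatter. For compound 4 the estimated value is 250000 nM, with an expected range from 90000 nM to 600000 nM.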

Compound 4, concentration for 50% growth inhibition: > 599000 nM
Compound 4: no number, only a limit; the forecaster's own chance of this, stated with the estimate: 25%; middle value at least 2.3-fold (0.37 log units) from the limit.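

The change to 4-chlorophenyl is the first among these compounds to touch the phenyl, as the steps from compound 1 to compound 2 and to compound 3 replaced the chloro already present. In this assay compound 4 yields a limit and not a number: the limit of > 599000 nM in this assay, at which 1 of the 4 values shown sits. The step is an at least 1.6-fold higher number from compound 1 to compound 4 (0.22 log units; that floor lies within the scatter), so chloro in place of hydrogen at this position gives no sign of stronger inhibition of growth, and compound 1 remains the only one of the four with a true number.

Going by these compounds, how far the true value of compound 4 lies from that of compound 1 stays open, and the steps among the limits of compound 2, compound 3 and compound 4 cannot be read. Also open, on these data alone, is how fluoro or a nitrile on this phenyl, or an amide in place of the carboxylic acid, would read in this assay.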